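Replacing 3-(methylsulfanyl)propyl with 3-fluorophenyl on a shared core

The compounds below may be only part of what the source reports. "The series", "measured", "known", "first", "only" and "open" are said of these compounds alone.

In an ADME assay on MT4 cells (Homo sapiens) for cytotoxicity (on this read-out lower numbers stand for higher toxicity in this test and higher numbers for lower toxicity in this test), compound 1 (`CCNC(=S)Nc1cccc(C(F)(F)F)c1`) reaches only a limit of the assay, > 100000 nM. Compound 2 (`Fc1ccc(NC(=S)Nc2cccc(C(F)(F)F)c2)cc1`) gives 31000 nM. Compound 3 (`CSCCCNC(=S)Nc1cccc(C(F)(F)F)c1`) gives 43000 nM. Going by the values given here, the only measured number alongside it is that of compound 2, and the two lie within the scatter of each other.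

Compound 4 (`Fc1cccc(NC(=S)Nc2cccc(C(F)(F)F)c2)c1`) has not yet been measured. It differs from compound 3 by 3-fluorophenyl in place of 3-(methylsulfanyl)propyl on an amide-type nitrogen, with 3-fluorophenyl in place of 3-(methylsulfanyl)propyl on an amide-type nitrogen.

Two measured steps start from the limit of compound 1, an at least 3.2-fold lower number from compound 1 to compound 2 (0.50 log units; beyond the scatter) and an at least 2.3-fold lower number from compound 1 to compound 3 (0.36 log units; beyond the scatter), and show that both compound 2 and compound 3 give numbers beyond the scatter of that limit. The step that bears most directly is a 1.4-fold higher number from compound 2 to compound 3 (0.14 log units; within the scatter), which exchanges 4-fluorophenyl for the same 3-(methylsulfanyl)propyl group that compound 4 gives up. Compound 2 carries 4-fluorophenyl where compound 4 carries 3-fluorophenyl, so the small size of that step suggests no step beyond the scatter here. The expected outcome is a 1.4-fold lower number from compound 3 to compound 4 (0.16 log units; within the scatter), with no clear direction. Compound 4 is estimated at 30000 nM, with an expected range of 13000 nM to 70000 nM.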

Compound 4, half-maximal cytotoxic concentration: 20000 nM
Compound 4: middle estimate off by 1.5-fold (0.18 log units), on the high side; the range from low to high includes it.
By their numbers in this assay, from the lowest: compounds 4, 2 and 3 (each within the scatter of the next, the first and the last beyond it). At a limit, above all of these: compound 1.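

In this assay, 3-fluorophenyl in place of 3-(methylsulfanyl)propyl on the amide-type nitrogen gives a 2.2-fold lower number from compound 3 to compound 4 (0.33 log units; beyond the scatter), so this exchange of a chain for a fluorinated aromatic ring moves the number beyond the scatter, which the 4-fluorophenyl group in compound 2 did not do against the same chain. That contrast does not separate the two fluorophenyl groups, however: 3-fluorophenyl in place of 4-fluorophenyl gives a 1.6-fold lower number from compound 2 to compound 4 (0.19 log units; within the scatter), and compound 2 therefore stands against any general rule that an aromatic ring on this nitrogen gives a lower number than the chain. Against the ethyl group, 3-fluorophenyl gives an at least 5.0-fold lower number from compound 1 to compound 4 (0.69 log units; beyond the scatter), the widest step shown at this position, though its true size remains unknown since it starts from a limit: the limit of > 100000 nM in this assay, at which 1 of the 4 values shown sits.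

The compounds shown leave open how an unsubstituted phenyl or a chlorophenyl group would compare on this nitrogen. They also leave open whether a longer chain, or a chain ending in an amine or a carboxylic acid, would keep the number near that of the ethyl compound.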